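Aryl Exchange on the Benzophenone Carbonyl of Compound 2

A few compounds are considered here, and "the series" means these few. Any claim that something is new, unique, unknown or untested is made for them only; others in the source may bear on it.

Measured compounds:
compound 1 `COc1ccc(C(=O)c2ccc([N+](=O)[O-])cc2)cc1OC(=O)CCC(=O)OC[C@@H]1C=C[C@H](n2cc(C)c(=O)[nH]c2=O)O1`, 10200 nM
compound 2 `COc1ccc(C(=O)c2ccc(F)cc2)cc1OC(=O)CCC(=O)OC[C@@H]1C=C[C@H](n2cc(C)c(=O)[nH]c2=O)O1`, 8250 nM

In a functional assay on SGC-7901 cells (Homo sapiens) for antiproliferative activity, read by MTT assay, with a stated time of 48 h (on this read-out lower numbers stand for stronger inhibition and higher numbers for weaker inhibition), compound 1 gives 10200 nM and compound 2 gives 8250 nM. Within the data shown here, the one step between them, a 1.2-fold lower number from compound 1 to compound 2 (0.09 log units; within the scatter), is within the scatter, so compound 2 holds the lowest of the two numbers without standing apart from compound 1. Compound 3 `COc1cc(OC)c(C(=O)c2ccc(OC)c(OC(=O)CCC(=O)OC[C@@H]3C=C[C@H](n4cc(C)c(=O)[nH]c4=O)O3)c2)cc1OC` has not yet been measured. It differs from compound 2 by 2,4,5-trimethoxyphenyl in place of 4-fluorophenyl on a carbonyl carbon. Among the measured compounds shown here, no measured step exchanges the whole ring on that carbonyl carbon; the only step on that ring, a 1.2-fold lower number from compound 1 to compound 2 (0.09 log units; within the scatter), changed a single substituent and stayed within the scatter. On that footing compound 3 is expected to come out near compound 2, with a step of a 1.3-fold lower number from compound 2 to compound 3 (0.10 log units; within the scatter) that may well lie within the scatter. The estimate for compound 3 in this assay is 6500 nM, with a range from 2000 nM to 20000 nM.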

Compound 3, half-maximal inhibitory concentration: 2270 nM
Estimate against measurement, compound 3: 2.9-fold (0.46 log units) above; low and high end bracket the measured number.
By their numbers in this assay, from the lowest: compound 3; then compounds 2 and 1 (each within the scatter of the next).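

In this assay, among these compounds, the whole ring on the carbonyl carbon moves the number beyond the scatter, which the single substituent change on that ring did not do. With 2,4,5-trimethoxyphenyl in place of 4-fluorophenyl the result is a 3.6-fold lower number from compound 2 to compound 3 (0.56 log units; beyond the scatter), and with the same ring in place of 4-nitrophenyl it is a 4.5-fold lower number from compound 1 to compound 3 (0.65 log units; beyond the scatter); both steps are modest, and they run the same way from two compounds that lie within the scatter of each other. Nothing available accounts for this difference.

The methoxy groups of 2,4,5-trimethoxyphenyl enter together, so the compounds shown leave open whether the step depends on all of them or on only some. They also leave open how a dimethylamino group or a carboxylic acid on that ring would read in this assay.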